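The compounds below may be only part of what the source reports. "The series", "measured", "known", "first", "only" and "open" are said of these compounds alone.

Measured compounds:
compound 1 `O=c1[nH]c(=O)n([C@H]2C[C@H](O)[C@@H](CO)O2)cc1-c1cn(CCC(F)(F)C(F)(F)C(F)(F)C(F)(F)C(F)(F)C(F)(F)C(F)(F)C(F)(F)C(F)(F)C(F)(F)F)nn1`, a functional assay on ACHN cells (Homo sapiens) for antiproliferative activity, read by sulforhodamine B assay; a lower number here means a stronger inhibitor of growth, a higher number a weaker inhibitor of growth: 90.8 uM
compound 2 `O=c1[nH]c(=O)n([C@H]2C[C@H](O)[C@@H](CO)O2)cc1-c1cn(CCC(F)(F)C(F)(F)F)nn1`, this assay: 96.1 uM

Compound 1 gives the lowest of the two numbers, but compound 2 sits only a hair above it, and that gap is within the usual scatter; the two are indistinguishable on these data. Both carry the shared core with a triazole-linked fluorinated chain, and the chain length has not separated them.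

Compound 3 `O=c1[nH]c(=O)n([C@H]2C[C@H](O)[C@@H](CO)O2)cc1-c1cn(CCC(F)(F)C(F)(F)C(F)(F)C(F)(F)C(F)(F)C(F)(F)C(F)(F)C(F)(F)F)nn1` is the next member. It differs from compound 1 by fluoro in place of 1,1,2,2,2-pentafluoroethyl on a saturated chain carbon bound to two fluorine atoms and a saturated chain carbon, shortening the fluorinated chain by one segment while keeping everything else intact. With compound 1 and compound 2 giving values so close to one another in this assay, no step beyond the scatter is expected here; the estimated step of a 1.0-fold higher number from compound 1 to compound 3 (0.01 log units; within the scatter) is flat. For compound 3 the expected value in this assay is 93 uM, with a range of 50 uM to 180 uM.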

Compound 3, concentration for growth inhibition (reported as GI): 14.2 uM
Beside the measured number, compound 3's estimate is 6.5-fold (0.82 log units) above it; the measured number lies below the stated range.
By their numbers in this assay, from the lowest: compound 3; then compounds 1 and 2 (each within the scatter of the next).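

Chain length at this position does matter in this assay: fluoro in place of 1,1,2,2,2-pentafluoroethyl on a saturated chain carbon bound to two fluorine atoms and a saturated chain carbon gives a 6.4-fold lower number from compound 1 to compound 3 (0.81 log units; beyond the scatter), the first step in the series beyond the scatter. The effect does not follow chain shortening in any steady way, and compound 2 goes against such a trend: it has the shortest fluorinated chain of the three, yet its number lies within the scatter of that of compound 1. Nothing available here bears on why this step occurs.

It remains open whether the lower number of compound 3 marks a narrow optimum, since chain lengths just above and below it are not among the compounds shown. From the compounds shown here alone, it is also open whether a plain hydrocarbon chain, or a chain ending in an amine or a carboxylic acid, would keep this activity.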